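Fluoro to Methoxy on a Tosylated Core at the Limit

A few compounds are considered here, and "the series" means these few. Any claim that something is new, unique, unknown or untested is made for them only; others in the source may bear on it.

The measurement here is a functional assay on A549 cells (Homo sapiens) for cytotoxicity, read by MTT assay, with a stated time of 4 days; a higher number here means a weaker inhibitor, a lower number a stronger inhibitor. Compound 3, with the structure `Cc1ccc(S(=O)(=O)Oc2ccc3c(c2C)[C@H](Cn2cc(-c4ccc(F)cc4)nn2)[C@@]24CC(=O)[C@@](C)(CC[C@@H]32)C4)cc1`, reaches only the limit of this assay and not a number: > 20000 nM. Its nearest measured neighbour is compound 2, `Cc1ccc(S(=O)(=O)Oc2ccc3c(c2C)[C@H](Cn2cc(-c4ccc(Br)cc4)nn2)[C@@]24CC(=O)[C@@](C)(CC[C@@H]32)C4)cc1`, which in this assay likewise stops at a limit, > 20000 nM. The step that the two limits leave unreadable from compound 2 to compound 3, fluoro in place of bromo on an aromatic carbon, cannot be sized because of the limit of > 20000 nM in this assay, at which 3 of the 3 values shown sit. Compound 1, `COc1ccc(-c2cn(C[C@H]3c4c(ccc(O)c4C)[C@@H]4CC[C@@]5(C)C[C@]43CC5=O)nn2)cc1`, carries a methoxy on the same phenyl ring but a free hydroxyl in place of the tosylate of compound 3; in this assay compound 1 also gives only a limit, > 20000 nM.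

Compound 4 has the structure `COc1ccc(-c2cn(C[C@H]3c4c(ccc(OS(=O)(=O)c5ccc(C)cc5)c4C)[C@@H]4CC[C@@]5(C)C[C@]43CC5=O)nn2)cc1`. The change from compound 3 is methoxy in place of fluoro on an aromatic carbon. Among the measured compounds shown here, no measured step reports how methoxy in place of fluoro shifts the read-out, since every value shown is a limit. Compound 1, which already carries the methoxy, stays at the limit in this assay. Compound 4 is therefore expected to sit at or near the limit as well, with an estimated value of 30000 nM and a range from 10000 nM to 100000 nM. The step that the limit leaves unreadable from compound 3 to compound 4 is expected to be no larger than the usual scatter, and most likely not readable at all.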

Compound 4, half-maximal inhibitory concentration: > 20000 nM
Compound 4 ended at the assay's limit (the forecaster's own chance of this, stated with the estimate: 85%); the middle value lies beyond the limit too.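

The steps from compound 1, compound 2 and compound 3 to compound 4 cannot be read in this assay, because each of these compounds gives a limit and not a number: the limit of > 20000 nM in this assay, at which 4 of the 4 values shown sit.

The compounds shown leave open whether swapping bromo, fluoro or methoxy, or the tosylate for a free hydroxyl, changes the read-out at all.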